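The source may hold more compounds than are shown below. What is called first, only, known or untested is meant among the compounds shown, and "the series" means these compounds.

Working notes on the series.

Three compounds of the shared core carry numbers in a functional assay on A549 cells (Homo sapiens) for antiproliferative activity, read by MTT assay, with a stated time of 48 h; a higher number here means a weaker inhibitor, a lower number a stronger inhibitor. Compound 1 `O=C(/C=C/c1ccc(Br)cc1)Nc1ccc2ncnc(Nc3cccc(Br)c3)c2c1` gives 15.3 ug/mL, compound 2 `O=C(/C=C/c1ccccc1Cl)Nc1ccc2ncnc(Nc3cccc(Cl)c3)c2c1` gives 4.58 ug/mL, and compound 3 `O=C(/C=C/c1ccccc1Br)Nc1ccc2ncnc(Nc3cccc(Cl)c3)c2c1` gives 5.63 ug/mL. Among the measured compounds shown here, compound 3 stands second highest of the three; compound 2 is nearest, and the single measured step, a 1.2-fold higher number from compound 2 to compound 3 (0.09 log units; within the scatter), shows that bromo in place of chloro on an aromatic carbon moved nothing beyond the scatter. Compound 1 stands furthest from compound 3, yet the two differ in more than one place, so their values are only noted side by side.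

Compound 4 `O=C(/C=C/c1ccc([N+](=O)[O-])cc1)Nc1ccc2ncnc(Nc3cccc(Cl)c3)c2c1` is not yet measured. It differs from compound 3 in one place: 4-nitrophenyl in place of 2-bromophenyl on a double-bonded chain carbon bound to a double-bonded chain carbon. For the measured compounds named here, no measured step touches this ring in this way; the only step available concerns a bromo-for-chloro swap elsewhere and was within the scatter. Going by the values given here, a change of this kind therefore has no precedent here, and the expectation rests on the spread of the three numbers, which all fall within a modest band. Compound 4 is estimated at 8 ug/mL in this assay, with a range from 3 ug/mL to 22 ug/mL, meaning an expected step of a 1.4-fold higher number from compound 3 to compound 4 (0.15 log units; within the scatter), likely no more than the scatter.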

Compound 4, half-maximal inhibitory concentration: 5.26 ug/mL
Compound 4: middle estimate off by 1.5-fold (0.18 log units), on the high side; measured number inside the range.
By their numbers in this assay, from the lowest: compounds 2, 4 and 3 (each within the scatter of the next); then compound 1.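

In this assay, replacing the ring on a double-bonded chain carbon bound to a double-bonded chain carbon gives a 1.1-fold lower number from compound 3 to compound 4 (0.03 log units; within the scatter) when 2-bromophenyl leaves, and a 1.1-fold higher number from compound 2 to compound 4 (0.06 log units; within the scatter) when 2-chlorophenyl leaves. Earlier, only a bromo-for-chloro swap had been read; now 4-nitrophenyl, a different group in a different ring location from either halogen, also stays within the scatter at this place. No measurement on record explains this result.

Still open, going by these compounds, is whether an amine or a carboxylic acid on this ring, or a longer chain in its place, would also stay within the scatter. Compound 1, at 15.3 ug/mL in this assay, differs from each of the others in more than one place, so no single change can be tied to its number.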